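A few compounds are considered here, and "the series" means these few. Any claim that something is new, unique, unknown or untested is made for them only; others in the source may bear on it.

Compound 1 `NCCCCc1c[nH]c2c(F)cccc12` carries a chain ending in an amine on its core. In an assay on isolated protein (urine) for inhibition of Myeloperoxidase (Homo sapiens), with a stated time of 5 min (on this read-out higher numbers stand for weaker inhibition and lower numbers for stronger inhibition), compound 1 gives 6 nM. Compound 2 `N#CCCCc1c[nH]c2ccc(C(=O)O)cc12` carries a nitrile-ended chain and a carboxylic acid; in this assay compound 2 is reported as "not active" (no number reported). Compound 3 `CCCc1c[nH]c2ccc(F)cc12`, whose chain is a plain propyl, is known only by a limit of the assay: in this assay compound 3 gives > 100 nM. Among the three, compound 3 stands at the limit of > 100 nM in this assay, at which 1 of the 3 values shown sits, while compound 2 has no number at all. Compound 4 `NCCSCCc1c[nH]c2ccc(F)cc12` is not yet measured; it differs from compound 3 by (2-aminoethyl)sulfanyl in place of methyl on a saturated chain carbon, two bonds along the chain from an aromatic carbon. Compound 1, whose chain also ends in an amine, gives 6 nM in this assay. For compound 4 stronger inhibition is expected, a step of an at least 5.0-fold lower number from compound 3 to compound 4 (0.69 log units; beyond the scatter) from the limit. The estimated value for compound 4 is 20 nM, between 5 nM and 100 nM.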

Compound 4, half-maximal inhibitory concentration: 4 nM
The estimate for compound 4 lay 5.0-fold (0.70 log units) above the measured number; the whole stated range lies above it.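

In this assay, putting (2-aminoethyl)sulfanyl in place of methyl on a saturated chain carbon, two bonds along the chain from an aromatic carbon, gives an at least 25-fold lower number from compound 3 to compound 4 (1.39 log units; beyond the scatter), a large step beyond the scatter. Among the compounds shown here, the earlier compounds differ from each other in more than one place, so this is the first direct reading of a single change. The step is a minimum, as compound 3 is known only by a limit: the limit of > 100 nM in this assay, at which 1 of the 4 values shown sits.

The compounds shown leave open whether the amine or the sulfur matters more. An all-carbon chain ending in an amine, or a sulfur-containing chain without the amine, on this same core would separate the two.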